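The source may report more compounds than this note shows. Statements on the series, on what has been measured and on what is new or still open speak of the compounds shown alone.

Measured in a functional assay on NCI-H460 cells (Homo sapiens); on this read-out lower numbers stand for stronger inhibition and higher numbers for weaker inhibition:
- Compound 1 `COc1cc(NC(C)CCCNC(=O)NC(CO)(CO)CO)c2ncccc2c1`: > 100000 nM
- Compound 2 `COc1cc(NC(C)CCCNC(=O)NCCNC(=O)NCCCC(C)Nc2cc(OC)cc3cccnc23)c2ncccc2c1`: 18000 nM

Compound 1 has no true number on this read-out, only a limit of > 100000 nM. Its place is therefore known only as the limit of > 100000 nM in this assay, at which 1 of the 2 values shown sits, and how far it lies past that limit cannot be told.

Compound 2 does give a true number, 18000 nM, so inhibition can be measured in this family of structures.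

The next compound is compound 3 `CCOC(=O)NCCCC(C)Nc1cc(OC)cc2cccnc12`, which keeps the core of compound 1 and changes one end of the side chain: ethoxy in place of (2-hydroxy-1,1-bis(hydroxymethyl)ethyl)amino on a carbonyl carbon.

Within the data shown here, no measured pair shows what this exchange does, so any forecast here is uncertain. Among the measured compounds shown here, with compound 2 at 18000 nM as the only true number to lean on, a result in that region is expected. As far as these compounds go, the expected step of an at least 3.3-fold lower number from compound 1 to compound 3 (0.52 log units; beyond the scatter) points toward stronger inhibition, and its true size stays open. In this assay, the estimated value for compound 3 is 30000 nM, with an expected range of 8000 nM to 100000 nM.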

Compound 3, half-maximal inhibitory concentration: 38000 nM
Beside the measured number, compound 3's estimate is 1.3-fold (0.10 log units) below it; measured number inside the range.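

In this assay, putting ethoxy in place of (2-hydroxy-1,1-bis(hydroxymethyl)ethyl)amino on a carbonyl carbon gives an at least 2.6-fold lower number from compound 1 to compound 3 (0.42 log units; beyond the scatter), so the group at this end of the side chain does affect the read-out. Among these compounds, this is the first readable step at this position, and compound 3, with a single copy of the core, gives a true number of 38000 nM, whereas the only earlier true number came from a compound with two copies. The step is only a lower bound on the real change, because compound 1 has no true number and is known only by a limit: the limit of > 100000 nM in this assay, at which 1 of the 3 values shown sits.

A single exchange swaps the whole group at once, so it cannot separate the loss of the hydroxyl groups from the drop in size, since ethoxy differs from the group it replaces in both. As far as these compounds go, it also remains open how far this end can be taken, for example whether a longer chain such as butoxy, a simple amine or a carboxylic acid at the same place would move the number further, or back towards weaker inhibition.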